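From a Methoxy to a Methyl Group on the Benzyl Arm

The compounds below may be only part of what the source reports. "The series", "measured", "known", "first", "only" and "open" are said of these compounds alone.

Compound 1 `O=C(NC1CCN(Cc2cccc(C(F)(F)F)c2)CC1)c1cccc2ccccc12` and compound 2 `COc1ccc(CN2CCC(NC(=O)c3cccc4ccccc34)CC2)cc1` share one core and differ only in the group on a saturated chain carbon bound to an amine nitrogen in a ring. In an assay on isolated protein for displacement of a labelled ligand from D(4) dopamine receptor (Homo sapiens) (on this read-out higher numbers stand for weaker inhibition and lower numbers for stronger inhibition), compound 1 gives 119 nM, and compound 2 gives 223 nM. The step of a 1.9-fold higher number from compound 1 to compound 2 (0.27 log units; within the scatter) leaves the two within the scatter of each other, so compound 2 stands beside compound 1 rather than apart from it. Compound 3 `Cc1cccc(CN2CCC(NC(=O)c3cccc4ccccc34)CC2)c1` carries 3-methylphenyl in place of 4-methoxyphenyl on a saturated chain carbon bound to an amine nitrogen in a ring. Among the measured compounds shown here, the only measured step that bears on this change is the one from compound 1 to compound 2, which exchanged one substituted phenyl for another at the same place without moving the number beyond the scatter. No step beyond the scatter is therefore expected in this assay for compound 3. For compound 3 the expected step is a 1.3-fold lower number from compound 2 to compound 3 (0.12 log units; within the scatter). Compound 3 is estimated at 170 nM, with a range from 60 nM to 500 nM.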

Compound 3, inhibition constant: 77 nM
For compound 3 the middle estimate is 2.2-fold (0.34 log units) above the measured one; the measured number falls inside the stated range.
By their numbers in this assay, from the lowest: compounds 3, 1 and 2 (each within the scatter of the next, the first and the last beyond it).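

In this assay the exchange of one substituted phenyl for another at this place now registers: a 2.9-fold lower number from compound 2 to compound 3 (0.46 log units; beyond the scatter) is a modest step beyond the scatter, which the earlier exchange on this arm did not reach. By contrast a 1.5-fold lower number from compound 1 to compound 3 (0.19 log units; within the scatter) stays within the scatter, so methyl in place of trifluoromethyl on an aromatic carbon does not separate these two compounds. Nothing measured here accounts for either step.

The compounds shown leave open how much of the step from 4-methoxyphenyl to 3-methylphenyl belongs to the group itself and how much to where it sits, since the two change together. They also leave open how a benzyl arm carrying a hydroxyl group or an amine would read in this assay and whether it would stand within the scatter of these three compounds.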